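The compounds below may be only part of what the source reports. "The series", "measured", "known", "first", "only" and "open" are said of these compounds alone.

Measured in a functional assay on A-431 cells (Homo sapiens) for cytotoxicity, read by MTT assay, with a stated time of 72 h, tested at 100 uM; on this read-out higher numbers stand for more inhibition of growth at the one concentration tested and lower numbers for less inhibition of growth: compound 1 `N/C(=N\NC(=S)N1CCCC1)c1ccc(F)cn1` gives 85.6%; compound 2 `Cc1ccnc(/C(N)=N/NC(=S)N2CCSCC2)c1` gives 79.6%; compound 3 `N/C(=N\NC(=S)N1CCSCC1)c1ccccn1` gives 80.8%.

Compound 3 stands second highest of the three numbers, with compound 2 nearest and compound 1 furthest, both gaps within the scatter. Compound 4 `N/C(=N\NC(=S)N1CCSCC1)c1ccc(F)cn1` differs from compound 3 by fluoro in place of hydrogen on an aromatic carbon. Within the data shown here, the only measured single-point step is a number 1.2 percentage points higher from compound 2 to compound 3 (within the scatter), within the scatter; no measured step covers fluoro entering. Among the measured compounds shown here, compound 1 also carries a fluoro group but differs from compound 3 elsewhere as well, so its value shows only that a fluoro-bearing member sits within the scatter of compound 3. The expected step is therefore a number 1.2 percentage points higher from compound 3 to compound 4 (within the scatter), none beyond the scatter. Compound 4 is estimated at 82%, in the range 70% to 93%.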

Compound 4, percent growth inhibition at one concentration: 86.6%
Estimate against measurement, compound 4: 4.6 percentage points below, and the stated range covers the measured number.
By their numbers in this assay, from the lowest: compounds 2, 3, 1 and 4 (each within the scatter of the next).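

Placing fluoro on the aromatic carbon two atoms from the ring nitrogen gives a number 5.8 percentage points higher from compound 3 to compound 4 (within the scatter) in this assay, the first direct reading of this position. With that fluoro present, thiomorpholin-4-yl in place of pyrrolidin-1-yl on the thiocarbonyl carbon gives a number 1 percentage points higher from compound 1 to compound 4 (within the scatter), so neither single change moves the number beyond the scatter. No available evidence bears on these results.

Still open, as far as these compounds go, is whether chloro, methoxy or trifluoromethyl at this position would stay within the scatter. Also open, from the compounds shown here alone, is whether a morpholin-4-yl group on the thiocarbonyl carbon would do so.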